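Changing the Aryl Group on a Shared Core

A few compounds are considered here, and "the series" means these few. Any claim that something is new, unique, unknown or untested is made for them only; others in the source may bear on it.

Of the compounds shown here, three built on a shared core have been measured in a functional assay on PC-9 cells (Homo sapiens) for inhibition, read by MTT assay, with a stated time of 48 h, tested at 10 uM; on this read-out higher numbers stand for more inhibition at the one concentration tested (going by the name of the read-out) and lower numbers for less inhibition. Compound 1 `COc1cc(Nc2cc(NC(=O)Nc3c(Cl)cccc3Cl)ncn2)cc(OC)c1` gives 90%. Compound 2 `COc1ccc(C(F)(F)F)cc1Nc1cc(NC(=O)Nc2c(Cl)cccc2Cl)ncn1` gives 89%. Compound 3 `COc1cc(NC(=O)Nc2cc(Nc3ccc(C)c(F)c3)ncn2)cc(OC)c1` gives 77.5%, the lowest of the three numbers; it lies beyond the usual scatter below both compound 2 and compound 1, so its weaker inhibition at the one concentration tested looks real rather than noise.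

Compound 4 `COc1cc(NC(=O)Nc2cc(Nc3ccc(Br)cc3OC)ncn2)cc(OC)c1` has not yet been measured. It differs from compound 3 in one place: 4-bromo-2-methoxyphenyl in place of 3-fluoro-4-methylphenyl on a nitrogen on an aromatic ring. Everything else in the molecule is kept.

Within the data shown here, no two measured compounds differ from each other in only this place, so there is no measured step to lean on, and compounds 1 and 2 differ from compound 3 in more than one place, so their values say only that other groups at this nitrogen can go with high inhibition. The expected step of a number 2.5 percentage points higher from compound 3 to compound 4 (within the scatter) is therefore small, without a clear direction, and may well sit within the scatter. In this assay compound 4 is estimated to give about 80%, with a likely range from 62% to 92%.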

Compound 4, a percentage reported as inhibition, at one concentration (the size of the read-out at that concentration, not a potency): 83%
Compound 4: middle estimate off by 3 percentage points, on the low side, and the stated range covers the measured number.
By their numbers in this assay, from the lowest: compounds 3, 4, 2 and 1 (each within the scatter of the next, the first and the last beyond it).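

In this assay, putting 4-bromo-2-methoxyphenyl in place of 3-fluoro-4-methylphenyl on a nitrogen on an aromatic ring gives a number 5.5 percentage points higher from compound 3 to compound 4 (within the scatter), so at one concentration the two groups cannot be told apart. Among these compounds, this is the only measured step at this place, and it shows that two quite different sets of ring substituents, bromine with methoxy and fluorine with methyl, can sit on this nitrogen without a change that stands clear of the scatter, even though the entering group brings one hydrogen-bond acceptor and the leaving group brings none. Nothing measured here speaks to why the two groups read alike.

Both substituents on the ring change together in this step, so the compounds shown leave open what the bromine and the methoxy group each do alone, as a plain phenyl, 4-bromophenyl or 2-methoxyphenyl group on the same nitrogen would begin to tell. They also leave open whether an aromatic ring is needed here at all, which a cyclohexyl group or a short chain ending in an amine could test.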